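Swapping the aryl group on the ring nitrogen

This account rests on a few compounds, and the source may have more. Where it says the series, first, only, none or still open, it means among the compounds named here.

Measured compounds:
- compound 1, `COc1ccc(C)cc1N1C(=O)CSC1c1cccc(C(=O)NCCCCc2ccccc2)c1`: 79%
- compound 2, `O=C(NCCCCc1ccccc1)c1cccc(C2SCC(=O)N2c2ccccc2F)c1`: 80%
- compound 3, `COc1c(F)cccc1N1C(=O)CSC1c1cccc(C(=O)NCCCCc2ccccc2)c1`: 1%

Three compounds share one core and differ only in the aryl group on the amide-type nitrogen in the ring. In a functional assay on SJSA-1 cells (Homo sapiens) for inhibition, read by CCK-8 assay, with a stated time of 72 h, tested at 1 uM (a lower number here means less inhibition, a higher number more inhibition at the concentration tested (going by the name of the read-out)), compound 1 gives 79%, and compound 2 gives 80%; the step of a number 1 percentage points higher from compound 1 to compound 2 (within the scatter) is within the scatter. Compound 3 stands lowest of the three, with steps a number 78 percentage points lower from compound 1 to compound 3 (beyond the scatter) and a number 79 percentage points lower from compound 2 to compound 3 (beyond the scatter), both large.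

Compound 4, `COc1ccc(N2C(=O)CSC2c2cccc(C(=O)NCCCCc3ccccc3)c2)c(OC)c1`, is not yet measured. It differs from compound 3 by 2,4-dimethoxyphenyl in place of 3-fluoro-2-methoxyphenyl on an amide-type nitrogen in a ring. The two large steps above show that the 3-fluoro-2-methoxyphenyl carries the loss, while the other two aryl groups both sit high. Compound 4 returns to a 2-methoxy-bearing aryl group, as in compound 1, so a large rise is expected, a number 64 percentage points higher from compound 3 to compound 4 (beyond the scatter), because compound 1 gives 79%. Compound 4 is therefore estimated at 65% in this assay, within a range from 20% to 90%, the width reflecting that no 2,4-dimethoxyphenyl has yet been measured here.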

Compound 4, a percentage reported as inhibition, at one concentration (the size of the read-out at that concentration, not a potency): 85%
For compound 4 the middle estimate is 20 percentage points below the measured one; measured number inside the range.
By their numbers in this assay, from the lowest: compound 3; then compounds 1, 2 and 4 (each within the scatter of the next).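

Putting 2,4-dimethoxyphenyl in place of 3-fluoro-2-methoxyphenyl on the ring nitrogen gives a number 84 percentage points higher from compound 3 to compound 4 (beyond the scatter) in this assay, so this position also accepts an aryl group with two methoxy groups. With a number 5 percentage points higher from compound 2 to compound 4 (within the scatter) and a number 6 percentage points higher from compound 1 to compound 4 (within the scatter), compound 4 joins the two earlier high compounds, leaving compound 3 as the only low one among the four. Nothing available here explains why the 3-fluoro-2-methoxyphenyl group behaves so differently from the other three aryl groups.

These compounds leave open whether the fluorine itself matters, which a chlorine atom in its place on the 3-fluoro-2-methoxyphenyl group could test, and how an amine or a carboxylic acid on the aryl ring would fare. Readings at a single concentration also leave open whether compounds 1, 2 and 4 would differ in the size of their effect at other concentrations.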